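A few compounds are considered here, and "the series" means these few. Any claim that something is new, unique, unknown or untested is made for them only; others in the source may bear on it.

Working notes on the series in a functional assay on CHO cells with adenosine receptor A1 (Homo sapiens) as the target, read by cAMP accumulation and immunoassay, with a stated time of 6 min, tested at 10 uM; a higher number here means a weaker effect of the compound at the concentration tested, a lower number a stronger effect.

Of the compounds shown here, three have numbers so far. Compound 1 `Nc1scc(CN2CCN(c3ccc(F)cc3Cl)CC2)c1C(=O)c1ccc(Cl)cc1` gives -70% in this assay. Compound 2 `Nc1scc(CN2CCN(c3ccc([N+](=O)[O-])cc3)CC2)c1C(=O)c1ccc(Cl)cc1` gives -17%. Compound 3 `Nc1scc(CN2CCN(c3ccc(F)c(Cl)c3)CC2)c1C(=O)c1ccc(Cl)cc1` gives -78%, the lowest of the three, with compound 1 nearest and compound 2 furthest. The steps among them show a number 8 percentage points lower from compound 1 to compound 3 (within the scatter) and a number 61 percentage points lower from compound 2 to compound 3 (beyond the scatter), while a number 53 percentage points higher from compound 1 to compound 2 (beyond the scatter) runs the other way.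

Compound 4 `Nc1scc(CN2CCN(c3ccccc3Cl)CC2)c1C(=O)c1ccc(Cl)cc1` has not yet been measured in this assay. It differs from compound 3 in one place: 2-chlorophenyl in place of 3-chloro-4-fluorophenyl on an amine nitrogen in a ring. The step from compound 1 to compound 3, which swaps one chlorofluorophenyl for another on the same ring nitrogen, bears on this most directly and was within the scatter. The large steps involving compound 2 concern the nitrophenyl and do not speak to a chlorophenyl without fluorine, so they are set aside. With the 2-chlorophenyl sharing the chlorine position of compound 1, which gave -70%, the expected step is a number 13 percentage points higher from compound 3 to compound 4 (beyond the scatter), a small move toward weaker effect, likely inside the scatter. Compound 4 is therefore estimated at -65% with a range from -85% to -40% in this assay.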

Compound 4, a percentage reported as activity, at one concentration (the size of the read-out at that concentration, not a potency): -18%
Beside the measured number, compound 4's estimate is 47 percentage points below it; the measured number lies above the stated range.
By their numbers in this assay, from the lowest: compounds 3 and 1 (each within the scatter of the next); then compounds 4 and 2 (each within the scatter of the next).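

In this assay the aryl group on the amine nitrogen in the ring turns out to depend on a single fluoro: a number 52 percentage points higher from compound 1 to compound 4 (beyond the scatter) with hydrogen in its place, and a number 60 percentage points higher from compound 3 to compound 4 (beyond the scatter) with 2-chlorophenyl replacing 3-chloro-4-fluorophenyl. The earlier swap between the two chlorofluorophenyl groups stayed within the scatter, which made the aryl group look tolerant, but among the compounds shown a chlorine without fluoro does not keep the stronger effect of compound 1 and compound 3. The result also removes any separation between two quite different groups, with a number 1 percentage points lower from compound 2 to compound 4 (within the scatter) placing 2-chlorophenyl level with 4-nitrophenyl, so the two compounds lacking fluoro sit together, well apart from the two that carry it.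

Nothing on hand bears on what lies behind the loss of effect on removing the fluoro. Still open, as far as these compounds go, is whether fluoro carries the effect without any chlorine, as a plain 4-fluorophenyl would test, and whether a methyl, a methoxy or a bromine in the place of the fluoro would hold it.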